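This account rests on a few compounds, and the source may have more. Where it says the series, first, only, none or still open, it means among the compounds named here.

Compound 3 `CC1=NC(c2cn(S(=O)(=O)c3ccccc3Cl)c3ccc(C)cc23)CN1` is the point of departure. In an assay on isolated protein for inhibition of kallikrein-7 (Homo sapiens), read by fluorescence, with stated times of 10 min and 30 min (on this read-out lower numbers stand for stronger inhibition and higher numbers for weaker inhibition), compound 3 gives 1200 nM, the lowest number among the three measured compounds. Compound 1 `CC1=NC(c2cn(S(=O)(=O)c3ccccc3)c3ccc(C)cc23)CN1` gives 17000 nM in this assay, and compound 2 `CC1=NC(c2cn(S(=O)(=O)c3cccc(Cl)c3)c3ccc(C)cc23)CN1` gives 30000 nM. The step of a 14-fold lower number from compound 1 to compound 3 (1.15 log units; beyond the scatter) and the step of a 25-fold lower number from compound 2 to compound 3 (1.40 log units; beyond the scatter) both set compound 3 apart, whereas the step of a 1.8-fold higher number from compound 1 to compound 2 (0.25 log units; within the scatter) shows that compound 1 and compound 2 cannot be told apart on these numbers.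

Compound 4 `CC1=NC(c2cn(S(=O)(=O)c3ccccc3C)c3ccc(C)cc23)CN1` differs from compound 3 in one place: methyl in place of chloro on an aromatic carbon. Within the data shown here, the steps that bear on this change are a 14-fold lower number from compound 1 to compound 3 (1.15 log units; beyond the scatter) and a 25-fold lower number from compound 2 to compound 3 (1.40 log units; beyond the scatter), which together show that a chloro on the aromatic carbon ortho to the large group accounts for the low number of compound 3. Among the measured compounds shown here, no measured step exchanges that chloro for a methyl, so the effect of the exchange itself is unknown. A modest rise is therefore expected, a 2.1-fold higher number from compound 3 to compound 4 (0.32 log units; beyond the scatter), which may well fall within the scatter, with some chance of a larger loss if the methyl does not carry over the gain seen for the chloro.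

Compound 4 is accordingly estimated at 2500 nM in this assay, with a range from 800 nM to 8000 nM.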

Compound 4, half-maximal inhibitory concentration: 1000 nM
For compound 4 the middle estimate is 2.5-fold (0.40 log units) above the measured one; the range from low to high includes it.
By their numbers in this assay, from the lowest: compounds 4 and 3 (each within the scatter of the next); then compounds 1 and 2 (each within the scatter of the next).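

In this assay, the exchange of the chloro ortho to a large group for a methyl gives a 1.2-fold lower number from compound 3 to compound 4 (0.08 log units; within the scatter) and so leaves compound 3 and compound 4 indistinguishable on these numbers. The methyl also yields a 17-fold lower number from compound 1 to compound 4 (1.23 log units; beyond the scatter) and a 30-fold lower number from compound 2 to compound 4 (1.48 log units; beyond the scatter) as a large step, showing that the low number seen with 2-chlorophenyl is not confined to a chlorine: among the compounds shown, 2-methylphenyl serves equally well at this place, whereas the unsubstituted phenyl of compound 1 and the 3-chlorophenyl of compound 2 both give far higher numbers. Nothing measured here accounts for why the chloro and the methyl match in this assay.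

The compounds shown leave open whether a larger or different group on the same aromatic carbon, such as an ethyl, a methoxy, an amine or a carboxylic acid, would keep the number as low as in compound 3 and compound 4. They also leave open whether a methyl on the aromatic carbon that carries the chloro in compound 2 would give a number as high as that of compound 2.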